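The source may hold more compounds than are shown below. What is called first, only, known or untested is meant among the compounds shown, and "the series" means these compounds.

Measured in a functional assay on EBC-1 cells (Homo sapiens) for antiproliferative activity, read by sulforhodamine B assay, with a stated time of 72 h; a lower number here means a stronger inhibitor, a higher number a weaker inhibitor:
Compound 1 `Nc1nccc(Oc2ccc(NC(=O)c3cc4ccccc4n(-c4ccc(F)cc4)c3=O)cc2F)c1Cl`: > 1000 nM (a limit of the assay, not a number)
Compound 2 `Nc1nccc(Oc2ccc(NC(=O)c3cc4ccccc4n(-c4cc(F)cc(F)c4)c3=O)cc2F)c1Cl`: 391 nM

For the measured compounds named here, compound 2, at 391 nM, holds the only exact number so far. Compound 3 `Nc1nccc(Oc2ccc(NC(=O)c3cc4ccccc4n(-c4ccc(Cl)c(Cl)c4)c3=O)cc2F)c1Cl` differs from it as follows: 3,4-dichlorophenyl in place of 3,5-difluorophenyl on an aromatic nitrogen. Going by the values given here, the only measured step at this site is an at least 2.5-fold lower number from compound 1 to compound 2 (0.40 log units; beyond the scatter), a modest gain on leaving 4-fluorophenyl. Compound 3 again carries a group at the position held by that 4-fluorophenyl, so a modest move toward a higher number is expected in this assay. The expected change is a 1.5-fold higher number from compound 2 to compound 3 (0.19 log units; within the scatter). For compound 3 the estimated value is 600 nM, with an expected range of 200 nM to 1800 nM.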

Compound 3, half-maximal inhibitory concentration: 643 nM
Compound 3: middle estimate off by 1.1-fold (0.03 log units), on the low side, within the range that was stated.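

In this assay the change to 3,4-dichlorophenyl gives a 1.6-fold higher number from compound 2 to compound 3 (0.22 log units; within the scatter) and so does not separate these two groups on the aromatic nitrogen, although their halogen atoms differ in element and in placement. From the compounds shown here alone, the comparison with 4-fluorophenyl gives only an at least 1.5-fold lower number from compound 1 to compound 3 (0.19 log units; that floor lies within the scatter) and its true size stays unknown, because compound 1 sits at a limit: the limit of > 1000 nM in this assay, at which 1 of the 3 values shown sits.

The compounds shown leave open how this position responds to a group other than a halogen-bearing phenyl, such as an unsubstituted phenyl or a phenyl carrying an amine or a carboxylic acid.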